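A few compounds are considered here, and "the series" means these few. Any claim that something is new, unique, unknown or untested is made for them only; others in the source may bear on it.

Measured compounds:
compound 1 `Cc1ccc(S(=O)(=O)N(CC(=O)OC(C)(C)C)Cc2ccc([N+](=O)[O-])s2)cc1` — 3000 nM
compound 2 `CC(C)(C)OC(=O)CN(Cc1ccc([N+](=O)[O-])s1)S(=O)(=O)c1cccc2ccccc12` — 800 nM

In a functional assay on HEK293 cells for agonist activity at nuclear receptor subfamily 1 group D member 1 (Homo sapiens), read by a luciferase reporter, with a stated time of 24 h (on this read-out lower numbers stand for an effect already at smaller amounts and higher numbers for an effect only at larger amounts of compound), compound 1 gives 3000 nM, the higher of the two numbers. Compound 2 gives 800 nM, and the step of a 3.8-fold lower number from compound 1 to compound 2 (0.57 log units; beyond the scatter) is the only measured one here. Compound 3 `Cc1ccc(S(=O)(=O)N(Cc2ccc(Cl)cc2)Cc2ccc([N+](=O)[O-])s2)cc1` has not yet been measured. It differs from compound 1 by 4-chlorophenyl in place of tert-butoxycarbonyl on a saturated chain carbon bound to a sulfonamide nitrogen. Among the measured compounds shown here, the measured step from compound 1 to compound 2 changes the group on the sulfonyl sulfur, a different place in the molecule, so it does not speak to the change in compound 3; no measured pair varies the group on the chain carbon at the sulfonamide nitrogen. With nothing to lean on, the expectation for compound 3 rests on compound 1 itself: a step of no change at the digits printed from compound 1 to compound 3 (within the scatter) is expected, that is, none beyond the scatter, with a wide range around it. Compound 3 is estimated at 3000 nM, between 700 nM and 12000 nM.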

Compound 3, half-maximal effective concentration: 2500 nM
Estimate against measurement, compound 3: 1.2-fold (0.08 log units) above, and the stated range covers the measured number.
By their numbers in this assay, from the lowest: compound 2; then compounds 3 and 1 (each within the scatter of the next).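

In this assay, putting 4-chlorophenyl in place of tert-butoxycarbonyl on the saturated chain carbon bound to the sulfonamide nitrogen gives a 1.2-fold lower number from compound 1 to compound 3 (0.08 log units; within the scatter), so this position has now been varied and the two compounds cannot be told apart. The exchange is a large one on paper, since a group with no ring and two hydrogen-bond acceptors gives way to an aromatic ring with none, yet the read-out stays within its usual scatter. Nothing available explains why these two groups read alike.

Still open, as far as these compounds go, is whether this tolerance extends to other groups at this place, such as a carboxylic acid, an amine or a longer chain. It is also unknown whether naphthalen-1-yl on the sulfonyl sulfur would have the same effect alongside 4-chlorobenzyl as it does alongside (tert-butoxycarbonyl)methyl.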